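Swapping chloro for methoxy on a compound reported inactive

The compounds below may be only part of what the source reports. "The series", "measured", "known", "first", "only" and "open" are said of these compounds alone.

In a functional assay on HO8910 cells (Homo sapiens) for inhibition, read by MTT assay, with a stated time of 24 h, tested at 10 ug/mL (on this read-out lower numbers stand for less inhibition of growth and higher numbers for more inhibition of growth at the one concentration tested), compound 2 `O=C(CCCCC(S)CCS)Nc1ccc(Cl)cc1` is reported as "not active" (no number reported) and has no single number, so its place on the scale is known only in words. The only figure from this small set comes from a relative, compound 1 `O=C(CCCCC1CCSS1)Nc1ccccc1Cl` with 4.66% on the same test. Next in line is compound 3 `COc1ccc(NC(=O)CCCCC(S)CCS)cc1` which has not yet been measured. The structural change is confined to one spot: methoxy in place of chloro on an aromatic carbon is methoxy in place of chloro on an aromatic carbon, para to a large group. Among the compounds with values here, no measured step shows what such a swap does here. No step beyond the usual scatter is therefore expected in this assay and growth inhibition should remain small. For compound 3 the estimated inhibition is 5% with an expected range of 0% to 18% in this test.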

Compound 3, percent growth inhibition at one concentration: 4.14%
Beside the measured number, compound 3's estimate is 0.9 percentage points above it, within the range that was stated.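

In this assay, within the data shown here, compound 2 is reported only in words, without a number, and no step from it to compound 3 can be read. As far as these compounds go, what swapping chloro for methoxy does to growth inhibition stays open. No measured evidence bears on this result.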